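Oxygen for Sulfur in a Sulfonyl-Linked Ring, Twice

This account rests on a few compounds, and the source may have more. Where it says the series, first, only, none or still open, it means among the compounds named here.

This account concerns four compounds built around a sulfonyl group whose saturated chain carbon carries a five-membered non-aromatic ring with two hetero atoms. Compound 1 `O=S(=O)(CC1=NCCS1)C1C(c2ccccc2)=NN(c2ccccc2)C1c1ccccc1` has a core that is different from the core shared by compound 2 `Cc1ccc(C2CNN=C2S(=O)(=O)CC2=NCCS2)cc1` and compound 3 `Cc1ccc(C2CNN=C2S(=O)(=O)CC2=NCCO2)cc1`; the difference between the two cores is not broken down here. In a functional assay, tested at 100 ug/mL (on this read-out higher numbers stand for a stronger effect at the one concentration tested and lower numbers for a weaker effect), compound 1 is reported as "not active" (no number reported), with no number given. In this assay compound 2 gives 45.1%, and in this assay compound 3 gives 46.8%.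

Compound 3 differs from compound 2 by a group of 5 heavy atoms (3 carbon, 1 nitrogen, 1 oxygen; one five-membered non-aromatic ring with 2 hetero atoms) in place of a group of 5 heavy atoms (3 carbon, 1 nitrogen, 1 sulfur; one five-membered non-aromatic ring with 2 hetero atoms), on a saturated chain carbon bound to a sulfonyl sulfur. The step this change made is a number 1.7 percentage points higher from compound 2 to compound 3 (within the scatter). Compound 4 `O=S(=O)(CC1=NCCO1)C1C(c2ccccc2)=NN(c2ccccc2)C1c1ccccc1` is not yet measured. It differs from compound 1 by a group of 5 heavy atoms (3 carbon, 1 nitrogen, 1 oxygen; one five-membered non-aromatic ring with 2 hetero atoms) in place of a group of 5 heavy atoms (3 carbon, 1 nitrogen, 1 sulfur; one five-membered non-aromatic ring with 2 hetero atoms), on a saturated chain carbon bound to a sulfonyl sulfur, which is the same kind of change made from compound 2 to compound 3, at the same place on a saturated chain carbon bound to a sulfonyl sulfur, but on the core of compound 1 rather than the core shared by compound 2 and compound 3.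

For compound 4 in this assay, the expectation rests on the fact that compound 1 is reported as "not active" (no number reported) and that the same change gave a step of a number 1.7 percentage points higher from compound 2 to compound 3 (within the scatter), which lies within the scatter. Compound 4 is therefore expected to give about 5%, with a plausible range from 0% to 20%, and it may again be reported only as not active.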

Compound 4, a percentage reported as activity, at one concentration (the size of the read-out at that concentration, not a potency): 48.1%
The estimate for compound 4 lay 43.1 percentage points below the measured number; the whole stated range lies below it.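

In this assay, among the compounds shown here, compound 1 stands as "not active" (no number reported) while compound 4 gives 48.1%, so no step from compound 1 to compound 4 can be read. The compounds shown leave open how large the exchange of these two ring groups is on the core of compound 1, and how that core compares with the core shared by compound 2 and compound 3. Nothing given here bears on this result.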